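This account rests on a few compounds, and the source may have more. Where it says the series, first, only, none or still open, it means among the compounds named here.

Of the compounds shown here, three sharing one core have been measured in an ADME assay on MDCK cells (Canis lupus familiaris) for cytotoxicity, read by microscopy, with a stated time of 48 h; a lower number here means that less compound is tolerated, a higher number that more compound is tolerated. Compound 1 `C[C@H]1[C@H](NCc2sccc2C2CCCCC2)C[C@H]2C[C@@H]1C2(C)C` gives 1560 nM, compound 2 `C=Cc1ccsc1CN[C@@H]1C[C@H]2C[C@@H]([C@H]1C)C2(C)C` gives 50000 nM, and compound 3 `C[C@H]1[C@H](NCc2sccc2-c2ccccc2)C[C@H]2C[C@@H]1C2(C)C` gives 12500 nM, so compound 3 stands second highest of the three, nearest to compound 2 and furthest from compound 1. Compound 4 `C[C@H]1[C@H](NCc2sccc2-c2ccsc2)C[C@H]2C[C@@H]1C2(C)C` differs from compound 3 by thiophen-3-yl in place of phenyl on an aromatic carbon. Going by the values given here, the steps that bear on this exchange at the same aromatic carbon are an 8.0-fold higher number from compound 1 to compound 3 (0.90 log units; beyond the scatter) and a 4.0-fold lower number from compound 2 to compound 3 (0.60 log units; beyond the scatter); both were beyond the scatter, yet each swapped a non-aromatic group for phenyl, whereas here one aromatic ring replaces another. A step not beyond the scatter is therefore expected, no change at the digits printed from compound 3 to compound 4 (within the scatter). Compound 4 is estimated at 12500 nM, within a range from 4000 nM to 40000 nM.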

Compound 4, minimum cytotoxic concentration: 12500 nM
The estimate for compound 4 equals the measured number at the digits printed; the range from low to high includes it.
By their numbers in this assay, from the lowest: compound 1; then compounds 3 and 4 (each within the scatter of the next); then compound 2.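

In this assay, the swap of one aromatic ring for another on this aromatic carbon leaves the number unmoved, with no change at the digits printed from compound 3 to compound 4 (within the scatter). Thiophen-3-yl, with its ring sulfur, stands where phenyl stood relative to the other two groups, with a 4.0-fold lower number from compound 2 to compound 4 (0.60 log units; beyond the scatter) and an 8.0-fold higher number from compound 1 to compound 4 (0.90 log units; beyond the scatter). Nothing measured here accounts for this. Still open, going by these compounds, is whether a pyridine ring or a phenyl ring carrying a carboxylic acid would also match phenyl at this carbon. Whether an amine on the thiophen-3-yl ring would move the number also remains unanswered.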